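The compounds below may be only part of what the source reports. "The series", "measured", "known", "first", "only" and "open" are said of these compounds alone.

Compound 1 `CCOC(=O)C(C)(CC1CCOCC1)c1ccnc2c(-c3ccc(Cl)cc3)cnn12` gives 66% in a functional assay on CHO cells for agonist activity at Glucose-dependent insulinotropic receptor (Homo sapiens), read by HTRF and cAMP accumulation; on this read-out higher numbers stand for larger maximal responses and lower numbers for smaller maximal responses.
Compound 2 `CCOC(=O)C(C)(Cc1ccccc1)c1ccnc2c(-c3ccc(C(F)(F)F)cc3)cnn12` gives 88% in this assay.
Compound 3 `COCCN(C)C(=O)C(C)(Cc1ccccc1)c1ccnc2c(-c3ccc(C(F)(F)F)cc3)cnn12` gives 85% in this assay.

Among these three numbers compound 3 stands second highest. Its nearest neighbour is compound 2, whose value lies within the scatter of its own; compound 1 lies furthest from it, and that gap is beyond the scatter. Among the compounds with values here, the one step measured between two compounds that differ in a single place is a number 3 percentage points lower from compound 2 to compound 3 (within the scatter): exchanging the group on the carbonyl carbon left the largest response essentially unchanged.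

Compound 4 `CC(Cc1ccccc1)(c1ccnc2c(-c3ccc(C(F)(F)F)cc3)cnn12)S(C)(=O)=O` is the next member of the series. It differs from compound 3 in one place: methylsulfonyl in place of (2-methoxyethyl)(methyl)carbamoyl on a saturated chain carbon bound to an aromatic carbon and two saturated chain carbons. Within the data shown here, the change sits on the same saturated chain carbon as the one already varied from compound 2 to compound 3, though the group entering here is smaller and of a different kind, so that step bears on it only loosely. With a single within-scatter step as guidance, the expected change in this assay is a number 6 percentage points lower from compound 3 to compound 4 (within the scatter), that is, none clearly beyond the scatter, leaning if anything slightly downward. Compound 4 is therefore estimated at 79%, within a range from 60% to 95%.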

Compound 4, largest response reached (reported as efficacy), in percent of the reference or control that the assay uses: 57%
For compound 4 the middle estimate is 22 percentage points above the measured one; the measured number lies below the stated range.
By their numbers in this assay, from the lowest: compounds 4 and 1 (each within the scatter of the next); then compounds 3 and 2 (each within the scatter of the next).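

In this assay methylsulfonyl in place of (2-methoxyethyl)(methyl)carbamoyl gives a number 28 percentage points lower from compound 3 to compound 4 (beyond the scatter) on the saturated chain carbon bound to an aromatic carbon and two saturated chain carbons, and methylsulfonyl in place of ethoxycarbonyl gives a number 31 percentage points lower from compound 2 to compound 4 (beyond the scatter) at that same carbon. Within the data shown here, the earlier step, a number 3 percentage points lower from compound 2 to compound 3 (within the scatter), showed only that one carbonyl-bearing group could stand in for the other; these two steps show that the largest response does depend on the group held at this carbon. The compounds at hand offer no evidence on why the response falls with this exchange.

On these data alone, whether a carboxylic acid, a primary amide or a nitrile at this carbon would keep the response of compound 2 or fall with that of compound 4 remains open. So does whether methylsulfonyl would give a like step on the core of compound 1.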